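A few compounds are considered here, and "the series" means these few. Any claim that something is new, unique, unknown or untested is made for them only; others in the source may bear on it.

Compound 1 `COc1cc(/C=C2\CCC/C(=C\c3ccccc3F)C2=O)cc(OC)c1OC` gives 1500 nM in a functional assay on RKO cells (Homo sapiens) for antiproliferative activity, read by MTT assay, with a stated time of 72 h; a higher number here means a weaker inhibitor, a lower number a stronger inhibitor. Compound 2 `COc1cc(/C=C2\CCC/C(=C\c3ccc(O)c(O)c3)C2=O)cc(OC)c1OC` gives 3100 nM in this assay.

Compound 1 holds the lowest number of the two measured compounds; its nearest neighbour is compound 2, reached by a 2.1-fold higher number from compound 1 to compound 2 (0.32 log units; beyond the scatter), a change that swapped the 2-fluorophenyl for a 3,4-dihydroxyphenyl on a double-bonded chain carbon bound to a double-bonded ring carbon.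

The unmeasured compound 3 `COc1cc(/C=C2\CCC/C(=C\c3ccc(O)c(Cl)c3)C2=O)cc(OC)c1OC` differs from compound 1 in the same place: 3-chloro-4-hydroxyphenyl in place of 2-fluorophenyl on a double-bonded chain carbon bound to a double-bonded ring carbon. For the measured compounds named here, the only measured step that bears on it is the one from compound 1 to compound 2, which brought in a 3,4-dihydroxyphenyl and raised the number modestly. Since the 3-chloro-4-hydroxyphenyl also brings a hydroxyl into this position, a similar small rise in this assay is expected for compound 3, though one close to the edge of the scatter.

Compound 3 is therefore estimated at 2100 nM, within 900 nM to 4800 nM, an expected step of a 1.4-fold higher number from compound 1 to compound 3 (0.15 log units; within the scatter).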

Compound 3, half-maximal inhibitory concentration: 700 nM
Compound 3: middle estimate off by 3.0-fold (0.48 log units), on the high side, and the stated range ends above it.
By their numbers in this assay, from the lowest: compound 3; then compound 1; then compound 2.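

At this position, a hydroxy-bearing phenyl group does not by itself raise the number in this assay: the 3-chloro-4-hydroxyphenyl gives a 2.1-fold lower number from compound 1 to compound 3 (0.33 log units; beyond the scatter), the opposite direction to the step that brought in the 3,4-dihydroxyphenyl. Chloro in place of hydroxy on an aromatic carbon gives a 4.4-fold lower number from compound 2 to compound 3 (0.65 log units; beyond the scatter), the largest step among these three compounds, so among them the direction of the change from compound 1 turns on that single group. No evidence is available to account for this difference. As far as these compounds go, what a 3-chlorophenyl without the hydroxy, a 3-bromo-4-hydroxyphenyl or a 3-amino-4-hydroxyphenyl would give at this place stays open. So does whether compound 3 and compound 1 keep this order on any other cell line.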